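Aryl phosphate variation on the shared core

This account rests on a few compounds, and the source may have more. Where it says the series, first, only, none or still open, it means among the compounds named here.

Among the measured compounds shown here, compound 2 `O=C(O[C@H]1C[C@H](n2cc(F)c(=O)[nH]c2=O)O[C@@H]1COP(=O)(O)Oc1ccccc1)c1ccccc1` gives 810 nM in a functional assay on T98G cells (Homo sapiens) for cytotoxicity, read by MTT assay, with a stated time of 48 h (on this read-out lower numbers stand for stronger inhibition and higher numbers for weaker inhibition), and stands at the lowest of the two numbers measured so far. Compound 3 `CCCCCCCCCc1ccc(OP(=O)(O)OC[C@H]2O[C@@H](n3cc(F)c(=O)[nH]c3=O)C[C@@H]2OC(=O)c2ccccc2)cc1` gives 6740 nM in this assay. For the measured compounds named here, the only measured change on the aryl group attached to the phosphate oxygen is the step of an 8.3-fold higher number from compound 2 to compound 3 (0.92 log units; beyond the scatter). Compound 1 `CCOC(=O)C[n+]1cccc(O)c1` lacks the shared core altogether; in this assay compound 1 gives > 200000 nM, which is a limit of the assay and not a number, as recorded under (the limit of > 200000 nM in this assay, at which 1 of the 3 values shown sits).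

Compound 4 `O=C(O[C@H]1C[C@H](n2cc(F)c(=O)[nH]c2=O)O[C@@H]1COP(=O)(O)Oc1ccc2ncccc2c1)c1ccccc1` differs from compound 2 in one place: quinolin-6-yl in place of phenyl on an oxygen. Going by the values given here, the one step that bears on this change is an 8.3-fold higher number from compound 2 to compound 3 (0.92 log units; beyond the scatter), where enlarging the aryl group on the phosphate oxygen raised the number. The present change also enlarges that aryl group, though by a fused ring carrying one hydrogen-bond acceptor rather than by a nonyl chain, so the measured step is only a loose guide. A small rise in the number is therefore expected, a 2.2-fold higher number from compound 2 to compound 4 (0.35 log units; beyond the scatter), possibly no larger than the scatter. Compound 4 is estimated at 1800 nM in this assay, with a range from 500 nM to 6500 nM.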

Compound 4, half-maximal inhibitory concentration: 1300 nM
The estimate for compound 4 lay 1.4-fold (0.14 log units) above the measured number, and the stated range covers the measured number.
By their numbers in this assay, from the lowest: compounds 2 and 4 (each within the scatter of the next); then compound 3. At a limit, above all of these: compound 1.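

Quinolin-6-yl in place of phenyl on an oxygen whose other neighbour is phosphorus gives a 1.6-fold higher number from compound 2 to compound 4 (0.21 log units; within the scatter) in this assay, so this position accepts a fused aromatic ring carrying a ring nitrogen with no change that can be told from the scatter. Among the compounds shown here, until now, the only step at this aryl group was an 8.3-fold higher number from compound 2 to compound 3 (0.92 log units; beyond the scatter) for nonyl in place of hydrogen on an aromatic carbon, which left open whether any enlargement of the group would raise the number. The two steps now separate that reading: both changes add heavy atoms, yet compound 3 moves beyond the scatter and compound 4 does not, so added size alone does not account for the rise across these compounds.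

Still open, going by these compounds, is whether the ring nitrogen of quinolin-6-yl matters, which a carbon-only naphthyl group on the same oxygen would test, and how a butyl chain, an amine or a carboxylic acid on the phenyl ring would compare with nonyl. Nothing in the evidence at hand bears on the reason for either step.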